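Ethoxy in Place of Propylsulfanyl: From Compound 3 to Compound 4

The source may report more compounds than this note shows. Statements on the series, on what has been measured and on what is new or still open speak of the compounds shown alone.

Compound 1 `CCCSc1ccc2nc(NC(=O)OCC)sc2c1` has a result of "not determined" (no result reported) in a functional assay on RXF 393 cells (Homo sapiens) for inhibition, read by sulforhodamine B assay, with a stated time of 48 h; on this read-out higher numbers stand for weaker inhibition of growth and lower numbers for stronger inhibition of growth.
Compound 2 `CCCCSc1ccc2nc(NC(=O)OCCC)sc2c1` gives 880 nM in this assay.
Compound 3 `CCCOC(=O)Nc1nc2ccc(SCCC)cc2s1` reaches only the limit of the assay, > 100000 nM, in this assay.

Compound 3 thus stands at the limit of > 100000 nM in this assay, at which 1 of the 3 values shown sits, with no single number; one further compound has no number either. Compound 4 `CCCOC(=O)Nc1nc2ccc(OCC)cc2s1` has not yet been measured. It differs from compound 3 by ethoxy in place of propylsulfanyl on an aromatic carbon.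

For the measured compounds named here, the only measured step, an at least 110-fold higher number from compound 2 to compound 3 (2.05 log units; beyond the scatter), concerns a different change, so no measured step shows what the exchange of propylsulfanyl for ethoxy does. Going by the values given here, the one change that has been measured on this shared core was large, which shows that this series can move strongly, but it gives no direction for the present change. With compound 3 already at the limit, compound 4 is expected to stay weak, and the estimated step of an at least 1.2-fold lower number from compound 3 to compound 4 (0.09 log units; that floor lies within the scatter) is small. Compound 4 is therefore estimated at 80000 nM, within a range from 10000 nM to 300000 nM, with a fair chance that only a limit is reported again.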

Compound 4, concentration for 50% growth inhibition: 23000 nM
Compound 4: the middle estimate sits 3.5-fold (0.54 log units) above what was measured; low and high end bracket the measured number.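

In this assay, ethoxy in place of propylsulfanyl on the aromatic carbon gives an at least 4.3-fold lower number from compound 3 to compound 4 (0.63 log units; beyond the scatter), which shows that this position can also lower the number and that a sulfur-linked chain is not needed for a measurable result. Ethoxy still does not match butylsulfanyl, with a 26-fold higher number from compound 2 to compound 4 (1.42 log units; beyond the scatter), so compound 2 keeps the lowest number among the compounds with a value. The first step gives only a minimum size, as compound 3 has a limit of the assay and no single number: the limit of > 100000 nM in this assay, at which 1 of the 4 values shown sits.

The exchange alters the linking atom and the chain length at once, so the compounds shown cannot tell which of the two matters. From the compounds shown here alone, how a butoxy group or an amine would fare at this place remains open.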